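The compounds below may be only part of what the source reports. "The series", "measured", "known", "first", "only" and "open" are said of these compounds alone.

Of the compounds shown here, two have been measured so far in a functional assay on HepG2 cells (Homo sapiens) for antiproliferative activity, read by MTT assay, with a stated time of 24 h; a lower number here means a stronger inhibitor, a higher number a weaker inhibitor. In this test, compound 1 (`C=CCc1ccc(OCC(=O)OCC)c(-c2ccc(OCC(=O)OCC)c(CC=C)c2)c1`) gives 68900 nM, and compound 2 (`C=CCc1cc(-c2ccc(OC)cc2)cc(CC=C)c1O`) gives 69200 nM. These two values lie within the usual scatter of each other, so compound 2 stands level with compound 1 on the available numbers, and both are weak inhibitors in absolute terms.

The next compound, compound 3 (`C=CCc1cc(-c2ccc(OC)cc2)ccc1O`), is derived from compound 2 by a single change, with hydrogen in place of allyl on an aromatic carbon, ortho to a hydroxy group: hydrogen in place of allyl on an aromatic carbon. Going by the values given here, no measured pair in this small set differs in only one place, so there is no direct precedent for the size of this step. Compound 1, at 68900 nM, differs from compound 2 in more than one place and still gives a value within the scatter of it. A step beyond the scatter in this assay is therefore not expected in either direction. The estimated change, a 1.2-fold lower number from compound 2 to compound 3 (0.06 log units; within the scatter), is small. For compound 3 the expected value is 60000 nM, with an estimated range from 25000 nM to 130000 nM.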

Compound 3, half-maximal inhibitory concentration: > 100000 nM
Compound 3 gave a limit, no number (the forecaster's own chance of this, stated with the estimate: 10%); middle value at least 1.6-fold (0.22 log units) away from the limit.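

In this assay compound 3 gives > 100000 nM, which is a limit of the assay and not a number. Going by these compounds alone, at the aromatic carbon ortho to a hydroxy group, hydrogen in place of allyl gives an at least 1.4-fold higher number from compound 2 to compound 3 (0.15 log units; that floor lies within the scatter), the first step in this set that differs in one place only. That step has a floor and no upper end, so it does not establish a change beyond the scatter, although compound 2 keeps a measured value and compound 3 does not, and compound 3 is the only compound shown that sits at the limit: the limit of > 100000 nM in this assay, at which 1 of the 3 values shown sits.

On these data alone, it remains open how far compound 3 really lies from compound 2, and whether a methyl group, a propyl chain or a longer chain at this place would give a measured value as the allyl group does. As far as these compounds go, it also remains open whether the same exchange would act alike on the core of compound 1, or whether an amine or a carboxylic acid in place of the hydroxy group would alter the picture.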